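The compounds below may be only part of what the source reports. "The series", "measured", "known", "first", "only" and "open" are said of these compounds alone.

Measured compounds: compound 1 `Cc1nn(-c2ccccc2)c2nc(C(=O)N3NC(=O)/C(=C/c4ccc(Cl)cc4)N=C3c3ccccc3)[nH]c(=O)c12` gives 4430 nM in a functional assay on MCF7 cells (Homo sapiens) for cytotoxicity, read by MTT assay, with a stated time of 48 h; a lower number here means a stronger inhibitor, a higher number a weaker inhibitor; compound 2 `Cc1nn(-c2ccccc2)c2nc(C(=O)N3NC(=O)/C(=C/c4ccccc4)N=C3c3ccccc3)[nH]c(=O)c12` gives 120 nM; compound 3 `Cc1nn(-c2ccccc2)c2nc(C(=O)N3NC(=O)/C(=C/c4ccccc4)N=C3c3ccc(Cl)cc3)[nH]c(=O)c12` gives 12.3 nM.

Compound 2 stands second highest of the three numbers, between compound 3 and compound 1. Compound 4 `COc1ccc(/C=C2\N=C(c3ccccc3)N(C(=O)c3nc4c(c(C)nn4-c4ccccc4)c(=O)[nH]3)NC2=O)cc1` differs from compound 2 in one place: methoxy in place of hydrogen on an aromatic carbon, sitting on an aromatic carbon of a six-membered aromatic ring of carbon only, para to a large group. The same ring carried chloro in compound 1, and that step, a 37-fold lower number from compound 1 to compound 2 (1.57 log units; beyond the scatter), was large. The step on the other phenyl, a 9.8-fold lower number from compound 2 to compound 3 (0.99 log units; beyond the scatter), points the opposite way but on a different ring. A methoxy group is not chloro, so the direction is uncertain, yet a higher number is expected for compound 4 in this assay: a 4.2-fold higher number from compound 2 to compound 4 (0.62 log units; beyond the scatter), giving an estimate of 500 nM with a range from 100 nM to 3000 nM.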

Compound 4, half-maximal inhibitory concentration: 61.3 nM
Compound 4: middle estimate off by 8.2-fold (0.91 log units), on the high side, outside the stated range (below it).
By their numbers in this assay, from the lowest: compound 3; then compounds 4 and 2 (each within the scatter of the next); then compound 1.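

In this assay, putting methoxy on this ring carbon, para to a large group, leaves the number within the scatter of the unsubstituted phenyl (a 2.0-fold lower number from compound 2 to compound 4 (0.29 log units; within the scatter)). Chloro at the same place therefore stands apart among these three groups, as the comparison with methoxy also shows (a 72-fold lower number from compound 1 to compound 4 (1.86 log units; beyond the scatter)), so a substituent here does not in itself bring a large rise in the number. Nothing available explains why chloro differs from methoxy. From the compounds shown here alone, whether an amine, a carboxylic acid or a longer chain at this place would match hydrogen and methoxy or chloro stays open.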